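The source may report more compounds than this note shows. Statements on the series, on what has been measured and on what is new or still open speak of the compounds shown alone.

Working notes on the dithiocarbamate series built on the shared core of compound 1.

Going by the values given here, compound 1 `Nc1nc(N)c2cc(CSC(=S)N3CCN(C4CCCCC4)CC3)ccc2n1` gives 4050 nM in a functional assay on HT-29 cells (Homo sapiens) for antiproliferative activity, read by MTT assay, with a stated time of 72 h (a higher number here means a weaker inhibitor, a lower number a stronger inhibitor), the highest of the three numbers measured so far. Compound 2 `COc1ccc(N2CCN(C(=S)SCc3ccc4nc(N)nc(N)c4c3)CC2)cc1` gives 1770 nM in this assay, and compound 3 `Cc1ccc(N2CCN(C(=S)SCc3ccc4nc(N)nc(N)c4c3)CC2)c(C)c1` gives 2970 nM. Replacing the cyclohexyl on the ring nitrogen by an aromatic group gave a 2.3-fold lower number from compound 1 to compound 2 (0.36 log units; beyond the scatter) and a 1.4-fold lower number from compound 1 to compound 3 (0.13 log units; within the scatter); between the two aromatic analogues the step is a 1.7-fold higher number from compound 2 to compound 3 (0.22 log units; within the scatter).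

Compound 4 `CC(=O)c1ccc(N2CCN(C(=S)SCc3ccc4nc(N)nc(N)c4c3)CC2)cc1` differs from compound 1 in a single place: 4-acetylphenyl in place of cyclohexyl on an amine nitrogen in a ring. The two measured steps from compound 1 are the ones that bear on this change, as each puts an aromatic ring in place of the cyclohexyl on the same ring nitrogen; one step was modest and beyond the scatter, the other within it. A modest lower number is therefore expected for compound 4, a 1.8-fold lower number from compound 1 to compound 4 (0.25 log units; within the scatter), with a fair chance that the step stays within the scatter. The estimate for compound 4 in this assay is 2300 nM, with a range from 1000 nM to 5500 nM.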

Compound 4, half-maximal inhibitory concentration: 2280 nM
The estimate for compound 4 lay 1.0-fold (0.00 log units) above the measured number; the range from low to high includes it.
By their numbers in this assay, from the lowest: compounds 2, 4, 3 and 1 (each within the scatter of the next, the first and the last beyond it).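

With 4-acetylphenyl on the ring nitrogen, a 1.8-fold lower number from compound 1 to compound 4 (0.25 log units; within the scatter) stays within the scatter, so of the three aromatic groups now measured in place of cyclohexyl, only the 4-methoxyphenyl of compound 2 gives a step beyond it. Acetyl in place of methoxy on an aromatic carbon gives a 1.3-fold higher number from compound 2 to compound 4 (0.11 log units; within the scatter), and 4-acetylphenyl in place of 2,4-dimethylphenyl gives a 1.3-fold lower number from compound 3 to compound 4 (0.11 log units; within the scatter); both lie within the scatter, so these aromatic groups cannot be told apart in this assay. No supporting data accompany these numbers to account for them.

As far as these compounds go, whether an amine or a carboxylic acid on the aromatic ring would give a step beyond the scatter remains open. The same holds for a benzyl group on the ring nitrogen.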